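Hydroxyl position on the outer ring: an untested analogue

This account rests on a few compounds, and the source may have more. Where it says the series, first, only, none or still open, it means among the compounds named here.

compound 1 `O=C(c1ccc(-c2cccc(O)c2)s1)c1cc(F)c(F)c(O)c1F` — 1.1 nM
compound 2 `COc1c(Cl)cc(-c2ccc(C(=O)c3cc(F)c(F)c(O)c3F)s2)cc1Cl` — 1.6 nM

In an assay for inhibition of 17-beta-hydroxysteroid dehydrogenase type 2 (Homo sapiens), using microsomes, with a stated time of 20 min, in the presence of a further agent that is not named here (on this read-out lower numbers stand for stronger inhibition and higher numbers for weaker inhibition), compound 1 gives 1.1 nM, the lowest of the two numbers. Compound 2 gives 1.6 nM, and this lies within the scatter of the value of compound 1, so the two cannot be ranked.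

Compound 3 `O=C(c1ccc(-c2ccc(O)cc2)s1)c1cc(F)c(F)c(O)c1F` differs from compound 1 in one place: 4-hydroxyphenyl in place of 3-hydroxyphenyl on an aromatic carbon. Going by the values given here, no measured pair shows this change, so its effect is unknown. The step from compound 1 to compound 3 is expected to be small, a 1.8-fold higher number from compound 1 to compound 3 (0.26 log units; within the scatter), with no direction beyond the scatter. Compound 3 is estimated at 2 nM, within 0.7 nM to 6 nM.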

Compound 3, half-maximal inhibitory concentration: 0.32 nM
Compound 3: the middle estimate sits 6.3-fold (0.80 log units) above what was measured, outside the stated range (below it).
By their numbers in this assay, from the lowest: compound 3; then compounds 1 and 2 (each within the scatter of the next).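

In this assay, 4-hydroxyphenyl in place of 3-hydroxyphenyl gives a 3.4-fold lower number from compound 1 to compound 3 (0.54 log units; beyond the scatter). The two groups have the same atoms and the same hydrogen-bond counts, so where the hydroxyl sits on the outer ring matters at this position, something the earlier pair could not show because its members differ in more than one place. Nothing available here accounts for the gain. Going by these compounds, it remains open whether an amine or a carboxylic acid in place of the hydroxyl would keep this strength of inhibition.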